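This account rests on a few compounds, and the source may have more. Where it says the series, first, only, none or still open, it means among the compounds named here.

In an assay for binding affinity, read by spectrophotometry (a lower number here means a stronger inhibitor, a higher number a weaker inhibitor), the three measured compounds lie within the scatter of one another: compound 1 `C[C@H](CCCN1CCCC1)Nc1ccnc2cc(Cl)ccc12` gives 140000 nM, compound 2 `C[C@H](CCCN1CCCCC1)Nc1ccnc2cc(Cl)ccc12` gives 130000 nM, and compound 3 `C[C@@H](CCCN(C)C)Nc1ccnc2cc(Cl)ccc12` gives 150000 nM. Next comes compound 4 `C[C@H](CCCN(C)C)Nc1ccnc2cc(Cl)ccc12`, compared with compound 3: the two compounds have the same atoms and bonds and differ only in configuration as drawn: 1 of 1 stereo elements differ; a stereocentre at a saturated chain carbon is drawn S in compound 3 and R in compound 4. Going by the values given here, the only measured step, a 1.1-fold lower number from compound 1 to compound 2 (0.03 log units; within the scatter), places piperidin-1-yl where pyrrolidin-1-yl stood, so it offers only indirect guidance. Among the compounds with values here, no measured pair isolates a change of configuration at this stereocentre. With that limited evidence, no shift beyond the scatter is expected in this assay, in either direction. The expected step, a 1.1-fold lower number from compound 3 to compound 4 (0.03 log units; within the scatter), is therefore small. Compound 4 is estimated at 140000 nM, with an expected range of 85000 nM to 220000 nM.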

Compound 4, half-maximal inhibitory concentration: 190000 nM
Beside the measured number, compound 4's estimate is 1.4-fold (0.13 log units) below it, within the range that was stated.
By their numbers in this assay, from the lowest: compounds 2, 1, 3 and 4 (each within the scatter of the next).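

Configuration at this saturated chain carbon now has a direct reading in this assay, a 1.3-fold higher number from compound 3 to compound 4 (0.10 log units; within the scatter), and the pair is a clean test of that single change: the fact that compounds 3 and 4 differ only in the configuration as drawn. Dimethylamino in place of either ring amine also stays inside the scatter, with a 1.4-fold higher number from compound 1 to compound 4 (0.13 log units; within the scatter) for pyrrolidin-1-yl and a 1.5-fold higher number from compound 2 to compound 4 (0.16 log units; within the scatter) for piperidin-1-yl. Neither the stereocentre nor these three amine groups separate the compounds.

Open, from the compounds shown here alone, is whether a primary amine or morpholin-4-yl at the chain end, or a longer chain, would give a step beyond the scatter.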